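Trimming the Amine on the Shared Core: Cytotoxicity Outlook

The compounds below may be only part of what the source reports. "The series", "measured", "known", "first", "only" and "open" are said of these compounds alone.

Compound 2 `Cc1cc(C)cc(Cn2c(=O)cc(N3CCNCC3)n(Cc3ccccc3)c2=O)c1` is the only one of the three measured compounds to give a number in an ADME assay on MT4 cells (Homo sapiens) for cytotoxicity, read by MTT assay, with a stated time of 4 days; on this read-out lower numbers stand for higher toxicity in this test and higher numbers for lower toxicity in this test; there compound 2 gives 16000 nM. Compound 1 `Cc1cc(C)cc(Cn2c(=O)cc(N)n(CC#N)c2=O)c1` reaches a limit of this test rather than a number, and in this assay compound 1 gives > 100000 nM. Compound 3 `Cc1cc(C)cc(Cn2c(=O)cc(N)n(Cc3ccncc3)c2=O)c1` likewise reaches a limit, and in this assay compound 3 gives > 100000 nM. Within the data shown here, the one measured step, a step that the two limits leave unreadable from compound 1 to compound 3, therefore cannot be read, because both of its ends sit at the limit of > 100000 nM in this assay, at which 2 of the 3 values shown sit.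

Compound 4 `CNc1cc(=O)n(Cc2cc(C)cc(C)c2)c(=O)n1Cc1ccccc1` differs from compound 2 in one place: methylamino in place of piperazin-1-yl on an aromatic carbon. Among the measured compounds shown here, no measured step changes exactly this group, so the only bearing comes from the pattern that compound 1 and compound 3, each carrying a plain amino group at that place, sit at the limit, while compound 2 with piperazin-1-yl is the sole compound to give a number. From this, compound 4 is expected to move toward lower toxicity, with an estimated step of a 3.8-fold higher number from compound 2 to compound 4 (0.57 log units; beyond the scatter) beyond the scatter. Compound 4 is accordingly estimated at 60000 nM in this assay, within a range from 20000 nM to 200000 nM, with a fair chance that only a limit is reported.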

Compound 4, half-maximal cytotoxic concentration: 65000 nM
For compound 4 the middle estimate is 1.1-fold (0.03 log units) below the measured one; the measured number falls inside the stated range.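

In this assay, among these compounds, methylamino in place of piperazin-1-yl on the aromatic carbon next to the ring nitrogen gives a 4.1-fold higher number from compound 2 to compound 4 (0.61 log units; beyond the scatter), the first step in this set whose size can be read, as the earlier step between compound 1 and compound 3 cannot be read. This shows that the number at this position responds to the exchange of a six-membered non-aromatic ring with 2 hetero atoms for a group of 2 heavy atoms without a ring, with the other substituents on the shared core held the same. It also shows that, with the smaller group in place, compound 4 still gives a number and does not reach a limit, while the values of compound 1 and compound 3 remain limits of the test: the limit of > 100000 nM in this assay, at which 2 of the 4 values shown sit.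

The compounds shown leave open whether the step goes with the loss of the ring or with the loss of the second ring nitrogen, a question that morpholin-4-yl or dimethylamino at this place would help to separate. They also leave open whether the same exchange gives a step of similar size when the benzyl group is replaced by another group, such as a longer alkyl chain.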